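Swapping pyridin-3-yl for pyridin-4-yl on compound 1

This account rests on a few compounds, and the source may have more. Where it says the series, first, only, none or still open, it means among the compounds named here.

In an ADME assay on L02 cells (Homo sapiens) for cytotoxicity, read by MTT assay, with a stated time of 24 h (on this read-out lower numbers stand for stronger inhibition and higher numbers for weaker inhibition), the measured compounds read:
- compound 1 (`COc1cc(/C=C2\CN(C)C/C(=C\c3cccnc3)C2=O)cc(OC)c1`): 18400 nM
- compound 2 (`COc1cc(/C=C2\CN(C)C/C(=C\c3cccnc3)C2=O)cc(OC)c1OC`): 14400 nM

For the measured compounds named here, compound 1 (18400 nM) and compound 2 (14400 nM) lie within the scatter of each other, so compound 1 stands level with the only other number available. Going by the values given here, the sole measured step is a 1.3-fold lower number from compound 1 to compound 2 (0.11 log units; within the scatter) and it concerns methoxy in place of hydrogen on an aromatic carbon, not the pyridinyl group. Compound 3 (`COc1cc(/C=C2\CN(C)C/C(=C\c3ccncc3)C2=O)cc(OC)c1`) has not yet been measured. It differs from compound 1 as follows: pyridin-4-yl in place of pyridin-3-yl on a double-bonded chain carbon bound to a double-bonded ring carbon. Among the compounds with values here, no measured step touches this group, so the data give neither size nor direction for the change. With compound 1 at 18400 nM as the only anchor, no shift beyond the scatter is expected in this assay. The expected step is a 1.2-fold lower number from compound 1 to compound 3 (0.06 log units; within the scatter). Compound 3 is estimated at 16000 nM, with an expected range from 8000 nM to 32000 nM.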

Compound 3, half-maximal inhibitory concentration: 13400 nM
Beside the measured number, compound 3's estimate is 1.2-fold (0.08 log units) above it; the measured number falls inside the stated range.
By their numbers in this assay, from the lowest: compounds 3, 2 and 1 (each within the scatter of the next).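

In this assay, for the compounds shown here, pyridin-4-yl in place of pyridin-3-yl on a double-bonded chain carbon bound to a double-bonded ring carbon gives a 1.4-fold lower number from compound 1 to compound 3 (0.14 log units; within the scatter), which gives this position a measured step of its own for the first time. The two groups count alike in heavy atoms, donors and acceptors, and exchanging one for the other does not separate compound 3 from compound 1 beyond the scatter in this read-out. Nothing measured here bears on why the two compounds read alike.

The compounds shown leave open whether a group of another kind at this place, such as pyridin-2-yl, a plain phenyl or a phenyl carrying a carboxylic acid, would move the number beyond the scatter. They also leave open whether the same swap would read alike on compound 2, which carries the added methoxy.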